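A few compounds are considered here, and "the series" means these few. Any claim that something is new, unique, unknown or untested is made for them only; others in the source may bear on it.

Three compounds of this series carry the same core and differ only in the amide attached through a carbonyl to the chain on the ring. Compound 1 `CCCCc1nc(C)c(CC(=O)N(C)C)c(=O)n1Cc1ccc(-c2ccccc2-c2nnn[nH]2)cc1` gives 0.018 mg/kg in an in vivo functional assay on the whole organism for inhibition, with Rattus norvegicus as the target; on this read-out higher numbers stand for an effect only at larger amounts of compound and lower numbers for an effect already at smaller amounts. Compound 2 `CCCCc1nc(C)c(CC(=O)N2CCC[C@H]2C(=O)OC)c(=O)n1Cc1ccc(-c2ccccc2-c2nnn[nH]2)cc1` gives 0.043 mg/kg. Compound 3 `CCCCc1nc(C)c(CC(=O)N2CC(C)OC(C)C2)c(=O)n1Cc1ccc(-c2ccccc2-c2nnn[nH]2)cc1` gives 0.029 mg/kg and stands second highest of the three numbers; its steps to both neighbours are within the scatter: a 1.6-fold higher number from compound 1 to compound 3 (0.21 log units; within the scatter) and a 1.5-fold lower number from compound 2 to compound 3 (0.17 log units; within the scatter). Within the data shown here, the only step that clears the scatter is a 2.4-fold higher number from compound 1 to compound 2 (0.38 log units; beyond the scatter), a modest one. All three amide variations therefore move the read-out little.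

Compound 4 `CCCCc1nc(C)c(CCC(=O)N2CCCCC2)c(=O)n1Cc1ccc(-c2ccccc2-c2nnn[nH]2)cc1` differs from compound 3 by ((piperidin-1-yl)carbonyl)methyl in place of (2,6-dimethylmorpholin-4-yl)carbonyl on a saturated chain carbon bound to an aromatic carbon; cut one bond further out, the change reads ((2,6-dimethylmorpholin-4-yl)carbonyl)methyl to 2-((piperidin-1-yl)carbonyl)ethyl. Among the measured compounds shown here, the amine swap itself resembles the measured steps, which were small; the longer chain has no precedent among the measured compounds. The expected step is a 1.2-fold higher number from compound 3 to compound 4 (0.08 log units; within the scatter), none beyond the scatter, with wider uncertainty for the chain. For compound 4 the estimate is 0.035 mg/kg, with an expected range from 0.012 mg/kg to 0.1 mg/kg.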

Compound 4, dose for half-maximal effect: 0.164 mg/kg
Compound 4: the middle estimate sits 4.7-fold (0.67 log units) below what was measured; measured number above the stated range.
By their numbers in this assay, from the lowest: compounds 1, 3 and 2 (each within the scatter of the next, the first and the last beyond it); then compound 4.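

In this assay this position proves less forgiving than the amine variations on the shorter chain suggested: the change to compound 4 gives a 5.7-fold higher number from compound 3 to compound 4 (0.75 log units; beyond the scatter), a 3.8-fold higher number from compound 2 to compound 4 (0.58 log units; beyond the scatter) and a 9.1-fold higher number from compound 1 to compound 4 (0.96 log units; beyond the scatter), all beyond the scatter. Compound 4 carries 2-((piperidin-1-yl)carbonyl)ethyl, so the longer chain and the piperidin-1-yl amide enter together, and the rise in the number cannot be assigned to either alone. Nothing available bears on the reason for this rise.

Still open, going by these compounds, is whether the piperidin-1-yl amide on the shorter chain would fall with compound 1, compound 2 and compound 3, or whether a dimethylamino amide on the longer chain would match compound 4. Also open, on these data alone, is how a still longer chain, or a carboxylic acid in place of the amide, would read at this position.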